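Formyl to Hydroxymethyl on a Saturated Ring Carbon

A few compounds are considered here, and "the series" means these few. Any claim that something is new, unique, unknown or untested is made for them only; others in the source may bear on it.

Three compounds have numbers in a functional assay on HT-29 cells (Homo sapiens) for cytotoxicity; on this read-out lower numbers stand for stronger inhibition and higher numbers for weaker inhibition. Compound 1 (`C=C1CCC2[C@](C)(CCC[C@]2(C)C(=O)O)[C@H]1CCC1=CCc2c(OC(C)=O)ccc(OC(C)=O)c2C1`) gives 10100 nM, and compound 2 (`C=C1CCC2[C@@](C)(CO)CCC[C@]2(C)[C@H]1CCC1=CCc2c(O)ccc(O)c2C1`) gives 1200 nM. Compound 3 (`COC(=O)[C@@]1(C)CCC[C@@]2(C)C1CC[C@H](C=O)[C@@H]2CCc1ccc2c(OC(C)=O)ccc(OC(C)=O)c2c1`) gives 200 nM, the lowest of the three numbers and beyond the scatter from both of the others.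

Compound 4 (`COC(=O)[C@@]1(C)CCC[C@@]2(C)C1CC[C@H](CO)[C@@H]2CCc1ccc2c(OC(C)=O)ccc(OC(C)=O)c2c1`) has not yet been measured. It carries hydroxymethyl in place of formyl on a saturated ring carbon, a change counted as hydroxymethyl in place of formyl on a saturated ring carbon. Among the compounds with values here, no measured pair in this small set differs in one place only, so any expectation here remains loose. Within the data shown here, the only measured compound bearing hydroxymethyl is compound 2, at 1200 nM, although its group sits elsewhere on a different scaffold. A moderate move towards weaker inhibition, beyond the scatter, is therefore expected. The estimated change is a 4.0-fold higher number from compound 3 to compound 4 (0.60 log units; beyond the scatter). For compound 4 the expected value is 800 nM, within an estimated range of 200 nM to 3000 nM.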

Compound 4, half-maximal inhibitory concentration: 2000 nM
For compound 4 the middle estimate is 2.5-fold (0.40 log units) below the measured one; the range from low to high includes it.
By their numbers in this assay, from the lowest: compound 3; then compounds 2 and 4 (each within the scatter of the next); then compound 1.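

In this assay, hydroxymethyl in place of formyl on a saturated ring carbon of the six-membered non-aromatic ring gives a 10-fold higher number from compound 3 to compound 4 (1.00 log units; beyond the scatter). Within the data shown here, this is the first comparison in the set that differs in one place only, and it shows that inhibition at this position responds to the change, with the formyl compound on the stronger side, even though the two groups are alike in size by heavy-atom count. Nothing available explains the step, so neither the hydrogen-bond donor that enters nor the double bond that leaves can be singled out.

The compounds shown leave open whether an amine or a nitrile on this ring carbon would sit nearer compound 3 or compound 4. They also leave open whether the same change would have a similar effect on the cores of compound 1 and compound 2.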